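The source may hold more compounds than are shown below. What is called first, only, known or untested is meant among the compounds shown, and "the series" means these compounds.

Measured so far:
- compound 1, `COc1cccc(NC(=O)COc2cc(C)nc3ccc(OC)cc23)c1`: 43000 nM
- compound 2, `COc1ccc2nc(C)cc(OCC(=O)Nc3ccc(Br)cc3)c2c1`: > 125000 nM
- compound 3, `COc1ccc2nc(C)cc(OCC(=O)Nc3ccccc3Cl)c2c1`: > 140000 nM

All three compounds share one core and differ only in the aryl group on the amide nitrogen. In an ADME assay on HepG2 cells (Homo sapiens) for cytotoxicity, read by trypan blue exclusion, with a stated time of 48 h, in the presence of a further agent that is not named here (on this read-out higher numbers stand for lower toxicity in this test and lower numbers for higher toxicity in this test), compound 1 gives 43000 nM. For compound 2 only a limit of the test is known, > 125000 nM, so its exact number is not available. For compound 3 the result is likewise a limit, > 140000 nM. Compound 2 therefore stands at one of the two limits, which is what the limit of > 125000 nM in this assay, at which 1 of the 3 values shown sits, states; the step of an at least 2.9-fold higher number from compound 1 to compound 2 (0.46 log units; beyond the scatter) and the step of an at least 3.2-fold higher number from compound 1 to compound 3 (0.51 log units; beyond the scatter) both run upward from compound 1, while the step that the two limits leave unreadable from compound 2 to compound 3 cannot be read because both ends are limits.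

Compound 4, `COc1ccc2nc(C)cc(OCC(=O)Nc3ccc(-c4ccccc4)cc3)c2c1`, is the next compound to be measured. It differs from compound 2 by phenyl in place of bromo on an aromatic carbon. Within the data shown here, no measured step exchanges bromo for phenyl, so none bears directly on this change; the two readable steps only show that changing the aryl group on the amide nitrogen can push the number up to a limit. The step of an at least 1.2-fold lower number from compound 2 to compound 4 (0.09 log units; that floor lies within the scatter) is therefore expected to be small and not readable beyond the scatter. Compound 4 is estimated at 100000 nM, within 30000 nM to 250000 nM, quite possibly again as a limit.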

Compound 4, half-maximal cytotoxic concentration: > 126000 nM
Compound 4 gave a limit, no number (the forecaster's own chance of this, stated with the estimate: 60%); middle value at least 1.2-fold (0.10 log units) from the limit.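

Compound 4 ends at a limit of this assay, not at a number: the limit of > 126000 nM in this assay, at which 1 of the 4 values shown sits. Compound 2 also stands at a limit, and the step from compound 2 to compound 4 cannot be read. The compounds shown leave open where the true numbers of compound 2 and compound 4 lie, and whether phenyl in place of bromo changes the result at all.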